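The compounds below may be only part of what the source reports. "The series", "measured", "known", "first", "only" and "open" are said of these compounds alone.

Compound 1 `Cc1cc(Nc2ccc(Cl)cc2)nc(SCc2nc3ccccc3[nH]2)n1` gives 33600 nM in a functional assay on MCF7 cells (Homo sapiens) for cytotoxicity, read by MTT assay, with a stated time of 72 h; on this read-out lower numbers stand for stronger inhibition and higher numbers for weaker inhibition.
Compound 2 `Cc1cc(NCCO)nc(SCc2nc3ccccc3[nH]2)n1` gives only a limit in this assay, > 100000 nM.
Compound 3 `Cc1ccc(Nc2cc(C)nc(SCc3nc4ccccc4[nH]3)n2)cc1` gives 56500 nM in this assay.

Among these, compound 3 carries the higher of the two actual numbers, but the gap to its nearest neighbour, a 1.7-fold higher number from compound 1 to compound 3 (0.23 log units; within the scatter), lies within the scatter, so the two cannot be told apart. The limit of compound 2 the limit of > 100000 nM in this assay, at which 1 of the 3 values shown sits, sets that compound apart from both.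

Compound 4 `Cc1cc(Nc2ccc(F)cc2)nc(SCc2nc3ccccc3[nH]2)n1` differs from compound 3 in one place: fluoro in place of methyl on an aromatic carbon. The measured step that bears most directly on this change is the earlier swap at the same place, a 1.7-fold higher number from compound 1 to compound 3 (0.23 log units; within the scatter), which stayed within the scatter. The other two steps, an at least 2.9-fold higher number from compound 1 to compound 2 (0.47 log units; beyond the scatter) and an at least 1.7-fold lower number from compound 2 to compound 3 (0.24 log units; that floor lies within the scatter), exchange the whole 4-chlorophenyl or 4-methylphenyl group for 2-hydroxyethyl and therefore say little about one substituent on that ring. With a single comparable step to go on, and that one within the scatter, no change beyond the scatter is expected from compound 3 to compound 4; the estimated step is a 1.3-fold lower number from compound 3 to compound 4 (0.13 log units; within the scatter). Compound 4 is thus expected to give about 42000 nM in this assay, within a range from 15000 nM to 110000 nM.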

Compound 4, half-maximal inhibitory concentration: 42200 nM
For compound 4 the middle estimate is 1.0-fold (0.00 log units) below the measured one; low and high end bracket the measured number.
By their numbers in this assay, from the lowest: compounds 1, 4 and 3 (each within the scatter of the next). At a limit, above all of these: compound 2.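

With fluoro, three different single-atom or single-carbon groups (chloro, methyl and fluoro) have now been compared at this aromatic carbon, para to a large group, and in this assay none of the swaps can be told apart: a 1.3-fold lower number from compound 3 to compound 4 (0.13 log units; within the scatter) and a 1.3-fold higher number from compound 1 to compound 4 (0.10 log units; within the scatter) both stay within the scatter, so this position has so far shown no clear response to the group it carries. The exchange of the whole group on the nitrogen reads differently, since an at least 2.3-fold lower number from compound 2 to compound 4 (0.37 log units; beyond the scatter) clears the scatter, which the floor of the step from compound 2 to compound 3 did not. That comparison rests on a limit of the assay for compound 2 rather than on a true number: the limit of > 100000 nM in this assay, at which 1 of the 4 values shown sits.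

On these data alone, whether a larger or quite different group on this carbon, such as a methoxy, a nitrile or a carboxylic acid, would move the number beyond the scatter remains open. Also open, as far as these compounds go, is what an unsubstituted phenyl, or a longer chain or an amine in place of the 2-hydroxyethyl on the nitrogen, would give.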